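Hydroxy in place of methoxy in a series at the limit

The source may report more compounds than this note shows. Statements on the series, on what has been measured and on what is new or still open speak of the compounds shown alone.

Values in a functional assay on B16 cells (Mus musculus) for antiproliferative activity, read by MTT assay, with a stated time of 72 h; on this read-out lower numbers stand for stronger inhibition and higher numbers for weaker inhibition:
- compound 1 `COc1cc(/C(=C/c2ccc(Br)cc2)C(C)O)cc(OC)c1OC`: > 100000 nM (a limit)
- compound 2 `COc1ccc(/C=C(/c2cc(OC)c(OC)c(OC)c2)C(C)O)cc1OC`: > 100000 nM (a limit)

Compound 2 gives > 100000 nM in this assay, which is a limit and not a number. Compound 1 gives > 100000 nM, which is also a limit. Both measured compounds share this position: the limit of > 100000 nM in this assay, at which 2 of the 2 values shown sit. No order between them can be read from these results.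

Compound 3 `COc1ccc(/C=C(/c2cc(OC)c(OC)c(OC)c2)C(C)O)cc1O` departs from compound 2 at one place: hydrogen in place of methyl on an oxygen on an aromatic ring. This puts hydrogen in place of methyl on an oxygen on an aromatic ring, turning methoxy to hydroxy.

Within the data shown here, no measured pair shows this change, so its size is not known from the data. The expected direction is toward stronger inhibition, though the result may well be another limit. The estimated step is an at least 6.6-fold lower number from compound 2 to compound 3 (0.82 log units; beyond the scatter), and it is an uncertain one. The expected value for compound 3 is 15000 nM, with an estimated range from 500 nM to 100000 nM.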

Compound 3, half-maximal inhibitory concentration: 16100 nM
Compound 3: middle estimate off by 1.1-fold (0.03 log units), on the low side; the range from low to high includes it.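

Hydrogen in place of methyl on an oxygen on an aromatic ring moves this series off the limit: in this assay, the change from methoxy to hydroxy gives an at least 6.2-fold lower number from compound 2 to compound 3 (0.79 log units; beyond the scatter). Among these compounds, compound 3, at 16100 nM, is the only one of the three compounds with a number rather than a limit, so this oxygen is a place where a single change registers in this read-out. The true size of the step cannot be read, and only its lower bound is known, because compound 2 stands at a limit and not at a number: the limit of > 100000 nM in this assay, at which 2 of the 3 values shown sit.

An amine or a fluorine at the same place could show whether the hydroxy itself matters or whether losing the methoxy is enough. As far as these compounds go, it also remains open whether methoxy to hydroxy gives a comparable step in the bromo-bearing compound 1, or at the other methoxy groups of compound 3.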